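This account rests on a few compounds, and the source may have more. Where it says the series, first, only, none or still open, it means among the compounds named here.

The study sets out four compounds built on a shared core, three of them already measured. Compound 1 `CCNCC(=O)Nc1cc(OC)ccc1C(=O)c1ccc(OC)c2c1C=CC(C)(C)O2` was tested in a functional assay on A2780 cells (Homo sapiens) for antiproliferative activity, read by MTT assay, with a stated time of 48 h (a higher number here means a weaker inhibitor, a lower number a stronger inhibitor), and compound 1 gives 4090 nM. Compound 3 `COc1ccc(C(=O)c2ccc(OC)c3c2C=CC(C)(C)O3)c(NC(=O)CN(C)C)c1` differs from it in one place, (dimethylamino in place of ethylamino on a saturated chain carbon bound to a carbonyl carbon), and in this assay compound 3 gives 3990 nM. The step of a 1.0-fold lower number from compound 1 to compound 3 (0.01 log units; within the scatter) is flat. Compound 2 `CCNCC(=O)Nc1cc(OC)ccc1C(=O)c1ccc2c(c1)C=CC(C)(C)O2` carries a different core; the difference between the cores of compound 1 and compound 2 is not broken down here. In this assay compound 2 gives 2070 nM, a value that lies within the scatter of both compound 1 and compound 3.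

Compound 4 `COc1ccc(C(=O)c2ccc3c(c2)C=CC(C)(C)O3)c(NC(=O)CN(C)C)c1` has not yet been measured in this assay. It differs from compound 2 by dimethylamino in place of ethylamino on a saturated chain carbon bound to a carbonyl carbon, the same change that separates compound 1 from compound 3, made at the same place. Going by the values given here, the one measured instance of this change, a 1.0-fold lower number from compound 1 to compound 3 (0.01 log units; within the scatter), left the number unmoved. The step expected for compound 4 is therefore estimated to be about as small, a 1.0-fold higher number from compound 2 to compound 4 (0.01 log units; within the scatter). Two instances are too few to claim a rule beyond these compounds, but nothing among them speaks against it. On that basis compound 4 is expected to give about 2100 nM in this assay. The range expected for compound 4 is estimated to run from 1000 nM to 4500 nM.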

Compound 4, half-maximal inhibitory concentration: 1020 nM
Estimate against measurement, compound 4: 2.1-fold (0.31 log units) above, and the stated range covers the measured number.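

On the second core, dimethylamino in place of ethylamino gives a 2.0-fold lower number from compound 2 to compound 4 (0.31 log units; beyond the scatter) in this assay, a modest step that stands beyond the usual scatter, whereas the same change on the first core left the number flat. Set side by side, the two steps cannot be told apart: the same change on two cores in this assay, a 1.0-fold lower number (0.01 log units; within the scatter) from compound 1 to compound 3 and a 2.0-fold lower number (0.31 log units; beyond the scatter) from compound 2 to compound 4, 2.0-fold (0.30 log units) apart, within the scatter of two such steps The pair therefore gives no firm sign that the core of compound 1 and the core of compound 2 respond differently to this change, and the result is compatible with carrying it from one to the other; but two instances, only one of them beyond the scatter, neither show that the step is the same on both cores nor rule out a modest difference between them.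

The compounds shown leave open whether other groups in the same place on a saturated chain carbon bound to a carbonyl carbon, such as an unsubstituted amine, diethylamino or morpholine, or a longer chain carrying the amine, would follow the same course. They also leave open whether the step seen here would hold on any core beyond these two.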